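Same Swap on a Second Core: Compound 4 Expected

The compounds below may be only part of what the source reports. "The series", "measured", "known", "first", "only" and "open" are said of these compounds alone.

Measured so far:
- compound 1 `Cc1ccc(-n2cc(-c3cccc(NS(=O)(=O)c4c[nH]c(=O)[nH]c4=O)c3)nn2)cc1`: 9430 nM
- compound 2 `O=c1[nH]cc(S(=O)(=O)Nc2cccc(-c3cn(-c4ccccc4F)nn3)c2)c(=O)[nH]1`: 16000 nM
- compound 3 `Cc1ccc(-n2cc(-c3ccc(NS(=O)(=O)c4c[nH]c(=O)[nH]c4=O)cc3)nn2)cc1`: 8350 nM

All three values come from a functional assay on SGC-7901 cells (Homo sapiens) for antiproliferative activity, read by MTT assay, with a stated time of 24 h; a lower number here means a stronger inhibitor, a higher number a weaker inhibitor. Compound 1 and compound 2 share a core and differ in one place: 2-fluorophenyl in place of 4-methylphenyl on an aromatic nitrogen. That change gave a 1.7-fold higher number from compound 1 to compound 2 (0.23 log units; within the scatter), so the two compounds cannot be told apart by this assay.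

Compound 3 is built from the same atoms as compound 1, joined differently; the difference between the two cores is not broken down here. Its value sits close to those of compound 1 and compound 2, and none of the three separates from the others beyond the usual scatter.

Compound 4 `O=c1[nH]cc(S(=O)(=O)Nc2ccc(-c3cn(-c4ccccc4F)nn3)cc2)c(=O)[nH]1` is not yet measured. It stands to compound 3 as compound 2 stands to compound 1, the same change made on the core of compound 3: 2-fluorophenyl in place of 4-methylphenyl on an aromatic nitrogen. Going by the values given here, with only one earlier example of this change, and that one lying within the scatter, the expectation is that compound 4 behaves much like compound 3. Compound 4 is therefore estimated at 14000 nM, with a likely range from 7000 nM to 30000 nM. Among the compounds with values here, this estimate means an expected step of a 1.7-fold higher number from compound 3 to compound 4 (0.22 log units; within the scatter), resting on the step seen from compound 1 to compound 2, a 1.7-fold higher number from compound 1 to compound 2 (0.23 log units; within the scatter), and on the single shared change; a second core may answer differently, which the range allows for.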

Compound 4, half-maximal inhibitory concentration: 7270 nM
Beside the measured number, compound 4's estimate is 1.9-fold (0.28 log units) above it; low and high end bracket the measured number.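

On the core of compound 3, 2-fluorophenyl in place of 4-methylphenyl gave a 1.1-fold lower number from compound 3 to compound 4 (0.06 log units; within the scatter) in this assay, so the two compounds cannot be told apart by this measurement. The same change on the two cores gave steps that also cannot be told apart: the same change on two cores in this assay, a 1.7-fold higher number (0.23 log units; within the scatter) from compound 1 to compound 2 and a 1.1-fold lower number (0.06 log units; within the scatter) from compound 3 to compound 4, 1.9-fold (0.29 log units) apart, within the scatter of two such steps. This shows that on both of these cores the swap stays within the scatter, so neither core gives a sign that the two groups differ in this assay; it does not show that the change carries a fixed size or direction from one core to another, and steps this small cannot separate a slight real effect from none at all, while two cores are too few to speak for the whole series.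

The compounds shown carry only 4-methylphenyl or 2-fluorophenyl on the aromatic nitrogen, so it remains open how a different kind of group there, such as a phenyl ring bearing an amine or a carboxylic acid, or a longer carbon chain, would read. As far as these compounds go, it also remains open whether the same picture would hold in other cell lines or over a different exposure time.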